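Hydrazone aryl swap: dichloro to hydroxy-methoxy in cytotoxicity

A few compounds are considered here, and "the series" means these few. Any claim that something is new, unique, unknown or untested is made for them only; others in the source may bear on it.

Compound 3 `COc1ccccc1-c1nnc(-c2ccc(C(=O)N/N=C/c3ccc(Cl)cc3Cl)cc2)o1` gives 78800 nM in an ADME assay on THP-1 cells (Homo sapiens) for cytotoxicity (a lower number here means a stronger inhibitor, a higher number a weaker inhibitor), the lowest of the three numbers. Compound 1 `COc1ccccc1-c1nnc(-c2ccc(C(=O)N/N=C/c3ccc([N+](=O)[O-])cc3)cc2)o1` gives 203000 nM and compound 2 `COc1ccccc1-c1nnc(-c2ccc(C(=O)N/N=C/c3ccccc3O)cc2)o1` gives 207000 nM, and the two stand within the scatter of each other (a 1.0-fold higher number from compound 1 to compound 2 (0.01 log units; within the scatter)). The steps to compound 3 are a 2.6-fold lower number from compound 1 to compound 3 (0.41 log units; beyond the scatter) and a 2.6-fold lower number from compound 2 to compound 3 (0.42 log units; beyond the scatter).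

Compound 4 `COc1ccc(/C=N/NC(=O)c2ccc(-c3nnc(-c4ccccc4OC)o3)cc2)c(O)c1` carries the change (2-hydroxy-4-methoxyphenyl in place of 2,4-dichlorophenyl on a carbon with a double bond to nitrogen). Going by the values given here, the nearest precedent is the step from compound 2 to compound 3, where the 2,4-dichlorophenyl replaced a 2-hydroxyphenyl and the number fell beyond the scatter. Reversing that change, with a methoxy added, is expected to raise the number modestly, so the step from compound 3 to compound 4 is estimated as a 2.3-fold higher number from compound 3 to compound 4 (0.36 log units; beyond the scatter). Compound 4 is therefore expected near 180000 nM, within 70000 nM to 400000 nM.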

Compound 4, half-maximal inhibitory concentration: 308000 nM
Compound 4: the middle estimate sits 1.7-fold (0.23 log units) below what was measured; the measured number falls inside the stated range.
By their numbers in this assay, from the lowest: compound 3; then compounds 1, 2 and 4 (each within the scatter of the next).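

In this assay, the 2-hydroxy-4-methoxyphenyl on this carbon does not keep the lower number seen with the 2,4-dichlorophenyl (a 3.9-fold higher number from compound 3 to compound 4 (0.59 log units; beyond the scatter)). Adding methoxy in place of hydrogen on an aromatic carbon leaves the number within the scatter (a 1.5-fold higher number from compound 2 to compound 4 (0.17 log units; within the scatter)), as does the swap for 4-nitrophenyl (a 1.5-fold higher number from compound 1 to compound 4 (0.18 log units; within the scatter)), so only compound 3 stands apart. No supporting data bear on the reason for this step.
Going by these compounds, whether one chlorine alone would give the lower number of compound 3 remains open. On these data alone, how a dimethylamino group or a carboxylic acid on this phenyl would read also remains open.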